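Replacing 3-cyanocyclobutyl with 1-(1,2,4-oxadiazol-3-yl)cyclopropyl

This account rests on a few compounds, and the source may have more. Where it says the series, first, only, none or still open, it means among the compounds named here.

In an ADME assay on MDCKII-LE cells (Canis lupus familiaris) for permeability (a lower number here means that the compound crosses the layer more slowly, a higher number that the compound crosses the layer faster), compound 1 `NC(=O)[C@@H](CCC(F)(F)F)N(CC12CC(c3ncon3)(C1)C2)S(=O)(=O)c1ccc(Cl)cc1` gives 19.3 10^-6 cm/s, compound 2 `N#Cc1ccc(CN([C@H](CCC(F)(F)F)C(N)=O)S(=O)(=O)c2ccc(Cl)cc2)cc1` gives 19.7 10^-6 cm/s and compound 3 `N#C[C@H]1C[C@@H](CN([C@H](CCC(F)(F)F)C(N)=O)S(=O)(=O)c2ccc(Cl)cc2)C1` gives 24.1 10^-6 cm/s, which places compound 3 within the scatter of both others. Compound 4 `NC(=O)[C@@H](CCC(F)(F)F)N(CC1(c2ncon2)CC1)S(=O)(=O)c1ccc(Cl)cc1` differs from compound 3 as follows: 1-(1,2,4-oxadiazol-3-yl)cyclopropyl in place of 3-cyanocyclobutyl on a saturated chain carbon bound to a sulfonamide nitrogen. Among the measured compounds shown here, three measured steps bear on this change. Compound 1 also carries a five-membered aromatic ring with 3 hetero atoms, and a 1.2-fold higher number from compound 1 to compound 3 (0.10 log units; within the scatter) is small, as are a 1.0-fold higher number from compound 1 to compound 2 (0.01 log units; within the scatter) and a 1.2-fold higher number from compound 2 to compound 3 (0.09 log units; within the scatter). All three lie within the scatter, so no step beyond it is expected in this assay. The expected step is a 1.2-fold lower number from compound 3 to compound 4 (0.08 log units; within the scatter) and carries no firm direction. For compound 4 the estimated value is 20 10^-6 cm/s, with an expected range of 11 10^-6 cm/s to 35 10^-6 cm/s.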

Compound 4, apparent permeability: 16.4 10^-6 cm/s
Estimate against measurement, compound 4: 1.2-fold (0.09 log units) above, within the range that was stated.
By their numbers in this assay, from the lowest: compounds 4, 1, 2 and 3 (each within the scatter of the next).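

In this assay the change on the saturated chain carbon bound to a sulfonamide nitrogen gives a 1.5-fold lower number from compound 3 to compound 4 (0.17 log units; within the scatter) and the two further steps a 1.2-fold lower number from compound 2 to compound 4 (0.08 log units; within the scatter) and a 1.2-fold lower number from compound 1 to compound 4 (0.07 log units; within the scatter) also lie within the scatter. This position has now carried four different groups, including 1-(1,2,4-oxadiazol-3-yl)cyclopropyl with its three-membered ring, without any step beyond the scatter in this read-out. Nothing measured here offers an explanation for this result. The compounds shown leave open whether an amine or a carboxylic acid at this position would also stay within the scatter of these four.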